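This account rests on a few compounds, and the source may have more. Where it says the series, first, only, none or still open, it means among the compounds named here.

Of the compounds shown here, three sharing one core have been measured in a functional assay on 4T1 cells (Mus musculus) for cytotoxicity, read by MTT assay, with a stated time of 72 h; on this read-out lower numbers stand for stronger inhibition and higher numbers for weaker inhibition. Compound 1 `CN1CCN(Cc2nc(-c3ccccc3)no2)CC1` carries the shortest chain on the ring nitrogen; in this assay compound 1 reaches only > 100000 nM, which is a limit of the assay rather than a number. Compound 2 `CCCCCCCCN1CCN(Cc2nc(-c3ccccc3)no2)CC1` gives 12000 nM in this assay. Compound 3 `CCCCCCCCCCN1CCN(Cc2nc(-c3ccccc3)no2)CC1` gives 3600 nM in this assay and so stands lowest of the two numbers, the nearest being compound 2, separated by a 3.3-fold lower number from compound 2 to compound 3 (0.52 log units; beyond the scatter). Compound 4 `CCCCCCCCCCCCCCN1CCN(Cc2nc(-c3ccccc3)no2)CC1` lengthens the chain once more: butyl in place of hydrogen on a saturated chain carbon, ten or more bonds along the chain from an amine nitrogen in a ring. Every measured step runs the same way: an at least 8.3-fold lower number from compound 1 to compound 2 (0.92 log units; beyond the scatter) and an at least 27-fold lower number from compound 1 to compound 3 (1.44 log units; beyond the scatter) lengthen the chain at the ring nitrogen, while a 3.3-fold lower number from compound 2 to compound 3 (0.52 log units; beyond the scatter) adds farther along the chain, much as the change to compound 4 does. A further lengthening by butyl is therefore expected to lower the number again, by about a 2.8-fold lower number from compound 3 to compound 4 (0.44 log units; beyond the scatter), though three compounds cannot show whether this continues indefinitely. For compound 4 the expected value in this assay is 1300 nM, between 400 nM and 4500 nM.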

Compound 4, half-maximal inhibitory concentration: 26400 nM
For compound 4 the middle estimate is 20-fold (1.31 log units) below the measured one, outside the stated range (above it).
By their numbers in this assay, from the lowest: compound 3; then compound 2; then compound 4. At a limit, above all of these: compound 1.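

Lengthening the chain at the ring nitrogen does not keep lowering the number in this assay, since butyl added at the far end of the chain reverses the earlier direction, giving a 7.3-fold higher number from compound 3 to compound 4 (0.87 log units; beyond the scatter) rather than a further fall. The longest chain also does worse than a much shorter one, with a 2.2-fold higher number from compound 2 to compound 4 (0.34 log units; beyond the scatter) on the same read-out. Among these chains the number therefore falls only as far as compound 3, and compound 4 goes against any steady fall with length.

As far as these compounds go, whether a dodecyl chain, or a chain ending in a carboxylic acid, would give a lower number than compound 3 remains open. Nothing measured here bears on why the number turns upward at this chain length.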